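The source may hold more compounds than are shown below. What is called first, only, known or untested is meant among the compounds shown, and "the series" means these compounds.

In an ADME assay on microsomes from liver (Homo sapiens) for metabolic stability (on this read-out lower numbers stand for slow clearance and higher numbers for fast clearance), compound 2 (`Cc1cccnc1N(C(=O)N1CCC(c2ccccc2)CC1)[C@@H]1CCCNC1`) gives < 8 mL.min-1.g-1, which is a limit and not a number. Compound 1 (`Cc1cccnc1N(C(=O)N1CCC(c2ccccc2F)CC1)[C@@H]1CCCNC1`) gives < 8 mL.min-1.g-1, also a limit. For the measured compounds named here, the only measured step, a step that the two limits leave unreadable from compound 1 to compound 2, therefore offers no size to carry forward. Compound 3 (`Cc1nccnc1N(C(=O)N1CCC(c2ccccc2)CC1)[C@@H]1CCCNC1`) differs from compound 2 by 3-methylpyrazin-2-yl in place of 3-methylpyridin-2-yl on an amide-type nitrogen, with 3-methylpyrazin-2-yl in place of 3-methylpyridin-2-yl on an amide-type nitrogen. Going by the values given here, no measured step changes this group, so no step beyond the scatter is expected in this assay. The estimated step is a step that the limit leaves unreadable from compound 2 to compound 3. Compound 3 is expected at 6 mL.min-1.g-1, with an estimated range of 4 mL.min-1.g-1 to 12 mL.min-1.g-1.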

Compound 3, intrinsic clearance in microsomes: < 8 mL.min-1.g-1
Compound 3: no number, only a limit (the forecaster's own chance of this, stated with the estimate: 70%); the middle value is on the limit's open side.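

No new step can be read between compound 2 and compound 3 in this assay, since both values are limits and not numbers: the limit of < 8 mL.min-1.g-1 in this assay, at which 3 of the 3 values shown sit.

The compounds shown leave open whether 3-methylpyrazin-2-yl in place of 3-methylpyridin-2-yl changes clearance at all.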